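Series notes: from compound 3 to compound 4

This account rests on a few compounds, and the source may have more. Where it says the series, first, only, none or still open, it means among the compounds named here.

Measured in a functional assay on IMR-32 cells (Homo sapiens) for cytotoxicity, read by sulforhodamine B assay, with a stated time of 48 h; a lower number here means a stronger inhibitor, a higher number a weaker inhibitor:
compound 1, `CC1=C(/C=C/C(=O)/C=C/c2ccc(Br)cc2)C(C)(C)CCC1`: 10400 nM
compound 2, `CC1=C(/C=C/C(=O)/C=C/c2ccc(F)cc2)C(C)(C)CCC1`: 7400 nM
compound 3, `CC1=C(/C=C/C(=O)/C=C/c2ccc(C)cc2)C(C)(C)CCC1`: 19200 nM

Compound 3 stands at the upper end of the three numbers. Against compound 1 the gap is a 1.8-fold higher number from compound 1 to compound 3 (0.27 log units; within the scatter), so those two cannot be told apart; against compound 2 it is a 2.6-fold higher number from compound 2 to compound 3 (0.41 log units; beyond the scatter), a modest but real separation.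

Compound 4, `CC1=C(/C=C/C(=O)/C=C/c2ccc([N+](=O)[O-])cc2)C(C)(C)CCC1`, differs from compound 3 in one place: nitro in place of methyl on an aromatic carbon. All three measured steps swap a single group at this same place, and all are small: a 1.4-fold lower number from compound 1 to compound 2 (0.15 log units; within the scatter), a 1.8-fold higher number from compound 1 to compound 3 (0.27 log units; within the scatter), a 2.6-fold higher number from compound 2 to compound 3 (0.41 log units; beyond the scatter). For the measured compounds named here, none of them involves nitro, so the direction for compound 4 is not fixed by the data; what they show is that single exchanges here have moved the number by only modest amounts, and that only the step between compound 2 and compound 3 reaches beyond the scatter.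

The expected step from compound 3 to compound 4 is therefore modest and toward a lower number, a 1.6-fold lower number from compound 3 to compound 4 (0.20 log units; within the scatter). For compound 4 the estimate in this assay is 12000 nM, with a range from 5000 nM to 30000 nM.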

Compound 4, half-maximal inhibitory concentration: 3200 nM
Beside the measured number, compound 4's estimate is 3.8-fold (0.57 log units) above it; measured number outside the range, below it.
By their numbers in this assay, from the lowest: compound 4; then compounds 2, 1 and 3 (each within the scatter of the next, the first and the last beyond it).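

In this assay, for the compounds shown here, this position proves more responsive than the exchanges among bromo, fluoro and methyl indicated: nitro in place of methyl on the aromatic carbon gives the largest step so far (a 6.0-fold lower number from compound 3 to compound 4 (0.78 log units; beyond the scatter)). Nitro also stands clear of the other two groups, both in place of fluoro (a 2.3-fold lower number from compound 2 to compound 4 (0.36 log units; beyond the scatter)) and in place of bromo (a 3.3-fold lower number from compound 1 to compound 4 (0.51 log units; beyond the scatter)), so compound 4 is the only compound whose steps to all the others lie beyond the scatter, and it is the strongest inhibitor of the four. Nothing available here explains why nitro separates from the other three groups at this position.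

Still open, from the compounds shown here alone, is whether the lower number is specific to nitro or would also appear with a nitrile, a trifluoromethyl group, a carboxylic acid or an amine on the same aromatic carbon. The compounds shown also leave open whether nitro would give a step of similar size at another place on the aromatic ring, or on a core changed elsewhere.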